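This account rests on a few compounds, and the source may have more. Where it says the series, first, only, none or still open, it means among the compounds named here.

Of the compounds shown here, two from one series have been measured in an assay on a cell-free system (plasma) for inhibition of Dipeptidyl peptidase 4 (Rattus norvegicus), read by fluorescence; a lower number here means a stronger inhibitor, a higher number a weaker inhibitor. Compound 1 `O=C([C@@H]1C[C@H](N2CCCN(c3ccc([N+](=O)[O-])cc3)CC2)CN1)N1CCSC1` gives 2.9 nM there. Compound 2 `O=C([C@@H]1C[C@H](N2CCN(c3ccc(Br)cc3)CC2)CN1)N1CCSC1` gives 9 nM in this assay, the higher of the two numbers, and its gap to compound 1 lies beyond the usual scatter. Compound 3 `O=C([C@@H]1C[C@H](N2CCN(c3ccc(Cl)c(Cl)c3)CC2)CN1)N1CCSC1` has not yet been measured; it differs from compound 2 by 3,4-dichlorophenyl in place of 4-bromophenyl on an amine nitrogen in a ring. Among the compounds with values here, no measured step of this kind is available, so no step beyond the scatter is expected from compound 2 to compound 3 in this assay. Compound 3 is therefore expected to give about 8 nM in this assay, within a range from 3 nM to 25 nM. The expected step is a 1.1-fold lower number from compound 2 to compound 3 (0.05 log units; within the scatter).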

Compound 3, half-maximal inhibitory concentration: 4.2 nM
For compound 3 the middle estimate is 1.9-fold (0.28 log units) above the measured one; the measured number falls inside the stated range.
By their numbers in this assay, from the lowest: compounds 1 and 3 (each within the scatter of the next); then compound 2.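

Compared with the earlier compounds, which offered no step at this position, the aryl group on an amine nitrogen in a ring now proves able to shift the number in this assay: 3,4-dichlorophenyl in place of 4-bromophenyl gives a 2.1-fold lower number from compound 2 to compound 3 (0.33 log units; beyond the scatter). The step is modest, but two chlorine atoms in place of one bromine cost nothing here. No measurement available explains this step. As far as these compounds go, it remains open whether the step comes from one chlorine or both, and how an aryl group bearing a nitrile or a methoxy group would compare.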